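Aziridine Carbonitrile Ureas: From Fluoro to Sulfamoyl

This account rests on a few compounds, and the source may have more. Where it says the series, first, only, none or still open, it means among the compounds named here.

Measured compounds:
compound 1, `N#CC1CN1C(=O)Nc1ccc(F)cc1`, 2100 nM
compound 2, `N#CC1CN1C(=O)Nc1ccc(Cl)cc1Cl`, 2200 nM
compound 3, `N#CC1CN1C(=O)NC1CCCCC1`, 2400 nM

In a functional assay on WiDr cells (Homo sapiens) for inhibition (on this read-out higher numbers stand for weaker inhibition and lower numbers for stronger inhibition), the three measured compounds sit close together. Compound 1 gives the lowest of the three numbers, yet its distance to compound 2 and to compound 3 falls within the scatter of repeated measurements, so no order among them can be read from these values. The aryl ureas and the cyclohexyl urea behave alike here.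

Compound 4, `N#CC1CN1C(=O)Nc1ccc(S(N)(=O)=O)cc1`, has not been measured. It differs from compound 1 by sulfamoyl in place of fluoro on an aromatic carbon. Going by the values given here, no step between measured compounds speaks to this change, and the three values above show no sensitivity to what sits on the urea nitrogen. On that basis the expected step from compound 1 to compound 4 is a 1.2-fold higher number from compound 1 to compound 4 (0.08 log units; within the scatter), meaning none beyond the scatter in either direction. Compound 4 is therefore estimated at 2500 nM in this assay, with a range from 900 nM to 7000 nM.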

Compound 4, half-maximal inhibitory concentration: > 38000 nM
Compound 4 gave a limit, no number; the forecaster's own chance of this, stated with the estimate: 5%; at least 15-fold (1.18 log units) between middle value and limit.
By their numbers in this assay, from the lowest: compounds 1, 2 and 3 (each within the scatter of the next). At a limit, above all of these: compound 4.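

In this assay, sulfamoyl in place of fluoro on an aromatic carbon gives an at least 18-fold higher number from compound 1 to compound 4 (1.25 log units; beyond the scatter), a large step that shows this place on the core of compound 1 is not indifferent to what sits there. Going by these compounds alone, the close values of the earlier compounds gave no sign of this, since no step among them could be read at this position. The value of compound 4 is a limit of the assay and not a number: the limit of > 38000 nM in this assay, at which 1 of the 4 values shown sits.

The compounds shown do not tell which part of the sulfamoyl group goes with this step, and they offer no measured property from which a cause could be given. As far as these compounds go, whether a methylsulfonyl group, a carboxylic acid or an amine on the same aromatic carbon would stay close to compound 1 or fall with compound 4 remains open.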